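Removing the Bromo Group from Compound 3

The source may report more compounds than this note shows. Statements on the series, on what has been measured and on what is new or still open speak of the compounds shown alone.

Measured so far in a functional assay on MCF7 cells (Homo sapiens) for inhibition, read by sulforhodamine B assay, with a stated time of 48 h; a higher number here means a weaker inhibitor of growth, a lower number a stronger inhibitor of growth:
- Compound 1 `CCOC(=O)c1nn(-c2ccc(Cl)cc2)c(-c2ccccc2)c1CNC(C)(C)C`: > 608000 nM; > 559000 nM (2 entries) (limits of the assay, not numbers)
- Compound 2 `CC(C)(C)NCc1c(C(=O)O)nn(-c2ccc(Cl)cc2)c1-c1ccc(Cl)cc1`: 246000 nM
- Compound 3 `CC(C)(C)NCc1c(C(=O)O)nn(-c2ccc(Cl)cc2)c1-c1ccc(Br)cc1`: 221000 nM

Only compound 2 and compound 3 give actual numbers, and those two numbers lie within the scatter of each other. Compound 2 therefore stands level with compound 3, which gives 221000 nM. Compound 1 reports > 608000 nM; > 559000 nM (2 entries), which is a limit of the assay.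

The next compound is compound 4 `CC(C)(C)NCc1c(C(=O)O)nn(-c2ccc(Cl)cc2)c1-c1ccccc1`, made from compound 3 by one change: hydrogen in place of bromo on an aromatic carbon. In words, hydrogen takes the place of bromo on an aromatic carbon, turning 4-bromophenyl into phenyl.

Going by the values given here, one measured step bears on this. It is a 1.1-fold lower number from compound 2 to compound 3 (0.05 log units; within the scatter), where bromo replaces chloro. That swap left the number within the scatter, but it exchanges one group for another and does not leave hydrogen behind, so it is only a partial guide. No step beyond the scatter is expected in this assay, and no firm direction can be expected either. The expected change is a 1.2-fold higher number from compound 3 to compound 4 (0.07 log units; within the scatter). For compound 4 the estimated value is 260000 nM, with an expected range from 120000 nM to 550000 nM.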

Compound 4, concentration for 50% growth inhibition: 496000 nM
Compound 4: the middle estimate sits 1.9-fold (0.28 log units) below what was measured; the range from low to high includes it.
By their numbers in this assay, from the lowest: compounds 3, 2 and 4 (each within the scatter of the next, the first and the last beyond it).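

In this assay, going by these compounds alone, this position had so far been probed only by exchanging one halogen for another, and that left the number within the scatter; replacing bromo with hydrogen is the first change here to go beyond it (a 2.2-fold higher number from compound 3 to compound 4 (0.35 log units; beyond the scatter)). The step is modest, and the matching removal of chloro does not clearly repeat it (a 2.0-fold higher number from compound 2 to compound 4 (0.30 log units; within the scatter)), which is printed as within the scatter, so the 4-bromophenyl compound alone stands clearly apart from the phenyl compound, and no general rule for halogens at this place can be drawn from these compounds. Nothing measured here explains why the number moves with this change.

As far as these compounds go, it remains open whether a fluoro, methoxy or amino group at the same place on the ring would give a number closer to that of the halogen compounds or to that of compound 4. From the compounds shown here alone, it is equally open how the number would respond elsewhere on the molecule, for example to an amide or a nitrile in place of the carboxylic acid.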